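A few compounds are considered here, and "the series" means these few. Any claim that something is new, unique, unknown or untested is made for them only; others in the source may bear on it.

- compound 1 `Cc1ccc(NS(=O)(=O)c2cccc(CCCCCCNC(=O)/C=C/c3cccnc3)c2)cc1`: 2.98 nM
- compound 2 `Cc1ccccc1NS(=O)(=O)c1cccc(CCCCCCNC(=O)/C=C/c2cccnc2)c1`: 0.456 nM

In a functional assay on K562 cells (Homo sapiens) for inhibition, read by CCK-8 assay, with a stated time of 72 h (on this read-out higher numbers stand for weaker inhibition and lower numbers for stronger inhibition), compound 1, at 2.98 nM, has the higher of the two numbers. Compound 3 `O=C(/C=C/c1cccnc1)NCCCCCCc1cccc(S(=O)(=O)Nc2ccc(Oc3ccccc3)cc2)c1` differs from it by one change phenoxy in place of methyl on an aromatic carbon, para to a large group. Among the measured compounds shown here, the only measured step that bears on this is modest but beyond the scatter: a 6.5-fold lower number from compound 1 to compound 2 (0.82 log units; beyond the scatter). That step swaps 4-methylphenyl for 2-methylphenyl, so it shows the number can move with a small change on the sulfonamide nitrogen, but gives no direction for phenoxy. The expected change is therefore small and of uncertain direction: a 1.5-fold lower number from compound 1 to compound 3 (0.17 log units; within the scatter). Compound 3 is estimated at 2 nM, with a range of 0.3 nM to 12 nM.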

Compound 3, half-maximal inhibitory concentration: 5.12 nM
Beside the measured number, compound 3's estimate is 2.6-fold (0.41 log units) below it; measured number inside the range.
By their numbers in this assay, from the lowest: compound 2; then compounds 1 and 3 (each within the scatter of the next).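

In this assay, swapping methyl for phenoxy on this aromatic carbon gives a 1.7-fold higher number from compound 1 to compound 3 (0.24 log units; within the scatter). The two numbers therefore cannot be told apart, so this position accepts a much larger group carrying its own aromatic ring without a measurable change in the number. The data offer no explanation for this tolerance. Still open, going by these compounds, is whether an amine or a carboxylic acid at this position would also leave the number unchanged. It is also unknown whether phenoxy would give a similar result at the position of the methyl in compound 2.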